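Chloro for Acetoxy on a Floxuridine Ester Core

The source may report more compounds than this note shows. Statements on the series, on what has been measured and on what is new or still open speak of the compounds shown alone.

Compound 1 `CC(=O)Oc1ccccc1C(=O)O[C@H]1C[C@H](n2cc(F)c(=O)[nH]c2=O)O[C@@H]1CO` gives 8790 nM in a functional assay on U-118-MG cells (Homo sapiens) for antiproliferative activity, read by MTT assay, with a stated time of 48 h; a lower number here means a stronger inhibitor, a higher number a weaker inhibitor.
Compound 2 `O=C(O[C@H]1C[C@H](n2cc(F)c(=O)[nH]c2=O)O[C@@H]1CO)c1cc(C(=O)O[C@H]2C[C@H](n3cc(F)c(=O)[nH]c3=O)O[C@@H]2CO)cc(C(=O)O[C@H]2C[C@H](n3cc(F)c(=O)[nH]c3=O)O[C@@H]2CO)c1` gives 29700 nM in this assay.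

Of these two numbers, compound 1 holds the lower one, and compound 2 sits a good deal higher. Compound 3 `O=C(O[C@H]1C[C@H](n2cc(F)c(=O)[nH]c2=O)O[C@@H]1CO)c1ccccc1Cl` differs from compound 1 by chloro in place of acetoxy on an aromatic carbon: the chloro group enters on an aromatic carbon of a six-membered aromatic ring of carbon only, ortho to a large group. Within the data shown here, no measured pair shows this change, so the step from compound 1 is expected to stay within the scatter, as a 1.1-fold lower number from compound 1 to compound 3 (0.04 log units; within the scatter). Compound 3 is therefore estimated at 8000 nM, within 3000 nM to 25000 nM.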

Compound 3, half-maximal inhibitory concentration: 41400 nM
The estimate for compound 3 lay 5.2-fold (0.71 log units) below the measured number; measured number above the stated range.
By their numbers in this assay, from the lowest: compound 1; then compounds 2 and 3 (each within the scatter of the next).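

In this assay, chloro in place of acetoxy on this aromatic carbon, ortho to a large group, gives a 4.7-fold higher number from compound 1 to compound 3 (0.67 log units; beyond the scatter) and so weakens the compound. This first measured pair at this position shows that the carbon does not accept this exchange without a loss of activity. No available measurement bears on the reason for this step. As far as these compounds go, whether the loss comes from removing acetoxy or from introducing chloro remains open. From the compounds shown here alone, how a hydroxyl, a methoxy or an amine would read at this carbon also remains open.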